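The source may hold more compounds than are shown below. What is called first, only, known or untested is meant among the compounds shown, and "the series" means these compounds.

Measured so far in a functional assay on the whole organism (COLO 205 cells) for inhibition, with Mus musculus as the target, read by polymerase chain reaction, in a xenograft, with a stated time of 8 h, at a dose of 40 mg/kg by the oral route; on this read-out higher numbers stand for more inhibition at the one dose given (going by the name of the read-out) and lower numbers for less inhibition:

compound 1 `Cc1cc(C)c(-c2ncc[nH]2)cc1NC(=O)c1ccc(OCc2ccccn2)cc1`: 88%
compound 2 `Cc1cc(C)c(-c2c[nH]nc2C)cc1NC(=O)c1ccc(OCc2ccccn2)cc1`: 75%

Compound 1 holds the highest of the two numbers; its nearest neighbour is compound 2, and the step of a number 13 percentage points lower from compound 1 to compound 2 (beyond the scatter) lies beyond the scatter.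

Compound 3 `Cc1cc(C)c(-c2ccc(N)nn2)cc1NC(=O)c1ccc(OCc2ccccn2)cc1` is not yet measured. It differs from compound 1 by 6-aminopyridazin-3-yl in place of 1H-imidazol-2-yl on an aromatic carbon.

Among the measured compounds shown here, the only measured step that bears on this change is the one at the same position, where a 3-methyl-1H-pyrazol-4-yl replaced the 1H-imidazol-2-yl: a number 13 percentage points lower from compound 1 to compound 2 (beyond the scatter), a modest loss. The entering 6-aminopyridazin-3-yl is a different ring size and a larger group than either, so that step is only a rough guide.

Because a number 13 percentage points lower from compound 1 to compound 2 (beyond the scatter) showed a modest fall on exchanging the five-membered ring, a step of similar size and direction is expected for compound 3, namely a number 14 percentage points lower from compound 1 to compound 3 (beyond the scatter).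

Compound 3 is therefore estimated at 74%, within 52% to 90%.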

Compound 3, a percentage reported as inhibition, in the whole organism at one dose (the size of the read-out at that dose, not a potency): 80%
For compound 3 the middle estimate is 6 percentage points below the measured one; measured number inside the range.
By their numbers in this assay, from the lowest: compounds 2, 3 and 1 (each within the scatter of the next, the first and the last beyond it).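

In this assay, among the compounds shown here, a six-membered aromatic ring is accepted at this position, where the earlier compounds carried only five-membered rings: 6-aminopyridazin-3-yl in place of 1H-imidazol-2-yl gives no separable change (a number 8 percentage points lower from compound 1 to compound 3 (within the scatter)). Against 3-methyl-1H-pyrazol-4-yl the read-out does not separate it either (a number 5 percentage points higher from compound 2 to compound 3 (within the scatter)), so compound 3 lies within the scatter of both neighbours, and only compound 1 and compound 2 stand apart. Nothing available explains these results or assigns a role to the added amine or ring nitrogens.

Going by these compounds, what a plain phenyl or a pyridin-3-yl group would give on this aromatic carbon remains open, and so does the effect of replacing the amine of the 6-aminopyridazin-3-yl with a methoxy group. A single dose and time also leave open whether compound 1 and compound 3 would stay inseparable under other conditions.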